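Methoxy for Trifluoromethyl on an Acylguanidine Core

The compounds below may be only part of what the source reports. "The series", "measured", "known", "first", "only" and "open" are said of these compounds alone.

Of the compounds shown here, three have been measured in a functional assay for inhibition of sodium/hydrogen exchanger (Oryctolagus cuniculus); on this read-out higher numbers stand for weaker inhibition and lower numbers for stronger inhibition. Compound 1 `COc1cc(C)c(C(=O)N=C(N)N)cc1S(C)(=O)=O` gives 16 nM. Compound 2 `Cc1cc(C(F)(F)F)c(S(C)(=O)=O)cc1C(=O)N=C(N)N` gives 37 nM, and compound 3 `CS(=O)(=O)c1cc(C(=O)N=C(N)N)ccc1C(F)(F)F` gives 140 nM, the highest number of the three. Two single changes connect them. Compound 1 arises from compound 2 by methoxy in place of trifluoromethyl on an aromatic carbon, and this gave a 2.3-fold lower number from compound 2 to compound 1 (0.36 log units; beyond the scatter). Compound 3 arises from compound 2 by hydrogen in place of methyl on an aromatic carbon, which gave a 3.8-fold higher number from compound 2 to compound 3 (0.58 log units; beyond the scatter).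

Compound 4 `COc1ccc(C(=O)N=C(N)N)cc1S(C)(=O)=O` has not yet been measured. It differs from compound 3 by methoxy in place of trifluoromethyl on an aromatic carbon. Going by the values given here, this is the same kind of change as the one from compound 2 to compound 1, but the surroundings are not identical: in compound 2 the changed carbon is also meta to a methyl group, whereas compound 3 carries no methyl group there. The step from compound 3 to compound 4 is expected to be a 2.3-fold lower number from compound 3 to compound 4 (0.37 log units; beyond the scatter), resting on the measured 2.3-fold lower number from compound 2 to compound 1 (0.36 log units; beyond the scatter). Compound 4 is therefore expected to give about 60 nM in this assay, with a likely range from 30 nM to 120 nM, because compound 3 gives 140 nM.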

Compound 4, half-maximal inhibitory concentration: 270 nM
Compound 4: the middle estimate sits 4.5-fold (0.65 log units) below what was measured, outside the stated range (above it).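

In this assay, methoxy in place of trifluoromethyl gave a 1.9-fold higher number from compound 3 to compound 4 (0.29 log units; within the scatter) and so made no clear difference on the core without the methyl group, which does not match the result on the core that carries it: the same change on two cores in this assay, a 2.3-fold lower number (0.36 log units; beyond the scatter) from compound 2 to compound 1 and a 1.9-fold higher number (0.29 log units; within the scatter) from compound 3 to compound 4, 4.5-fold (0.65 log units) apart, beyond the scatter of two such steps. Hydrogen in place of methyl also depends on its surroundings, giving a 17-fold higher number from compound 1 to compound 4 (1.23 log units; beyond the scatter) with methoxy present, a larger step than with trifluoromethyl present: the same change on two cores in this assay, a 3.8-fold higher number (0.58 log units; beyond the scatter) from compound 2 to compound 3 and a 17-fold higher number (1.23 log units; beyond the scatter) from compound 1 to compound 4, 4.5-fold (0.65 log units) apart, beyond the scatter of two such steps. These four compounds therefore show that the two changes do not act independently here and that a step measured on one core need not hold on another, but they do not show why, or how any further core would behave.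

The compounds shown leave open whether this dependence on the core also appears when an ethoxy group, an amine or a chlorine atom stands in place of methoxy. They also leave open what a longer chain in place of the methyl group would do.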